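The source may hold more compounds than are shown below. What is called first, only, known or untested is meant among the compounds shown, and "the series" means these compounds.

Measured so far:
compound 1 `Cc1nc(Nc2ccc(Cl)c(Cl)c2)sc1C(=O)/C=C/c1ccccc1`: 22700 nM
compound 2 `Cc1nc(Nc2ccc(Cl)cc2)sc1C(=O)/C=C/c1ccc(Cl)cc1`: > 25000 nM
compound 3 `COc1cc(/C=C/C(=O)c2sc(Nc3cccc(Cl)c3)nc2C)cc(OC)c1OC`: > 25000 nM

In a functional assay on NCI-H460 cells (Homo sapiens) for cytotoxicity, read by MTT assay (on this read-out higher numbers stand for weaker inhibition and lower numbers for stronger inhibition), compound 1 gives 22700 nM. For compound 2 the result is only a limit of the assay, > 25000 nM. Compound 3 likewise returns only a limit, > 25000 nM, so its standing among the three is known solely through (the limit of > 25000 nM in this assay, at which 2 of the 3 values shown sit). Compound 4 `COc1cc(/C=C/C(=O)c2sc(Nc3ccccc3C)nc2C)cc(OC)c1OC` has not yet been measured in this assay. It differs from compound 3 by 2-methylphenyl in place of 3-chlorophenyl on a nitrogen on an aromatic ring; cut one bond further out, the change reads (3-chlorophenyl)amino to (2-methylphenyl)amino. Among the compounds with values here, no measured pair shows this change. Because compound 3 returns only the limit > 25000 nM the expected step is a number no higher from compound 3 to compound 4 (the limit leaves the size open), none beyond the usual scatter. Compound 4 is therefore estimated at 25000 nM, within 10000 nM to 60000 nM, most probably reported again only as a limit.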

Compound 4, half-maximal inhibitory concentration: 6320 nM
For compound 4 the middle estimate is 4.0-fold (0.60 log units) above the measured one; the measured number lies below the stated range.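

In this assay, the group on the nitrogen proves able to move the read-out: 2-methylphenyl in place of 3-chlorophenyl gives an at least 3.9-fold lower number from compound 3 to compound 4 (0.59 log units; beyond the scatter). Within the data shown here, this is the first step here between compounds that differ in one place. Compound 3 stands only at a limit of the assay, so the full size of the step stays open: the limit of > 25000 nM in this assay, at which 2 of the 4 values shown sit.

This single swap cannot separate the loss of the chlorine from the arrival of the methyl or from the change in where the substituent sits. Going by these compounds, how a plain phenyl or a 2-chlorophenyl would read at this nitrogen also remains open.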